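The source may hold more compounds than are shown below. What is called first, only, known or untested is meant among the compounds shown, and "the series" means these compounds.

In a functional assay on the whole organism (strain Wistar) for inhibition, with Rattus norvegicus as the target, read by paw edema, with stated times of 30 min and 3 h, at a dose of 0.05 mmol/kg by the oral route (on this read-out higher numbers stand for more inhibition at the one dose given (going by the name of the read-out) and lower numbers for less inhibition), compound 1 `Cc1cc(O)ccc1C1=NN(c2ccc(S(C)(=O)=O)cc2)C(=O)CC1` gives 33.3%. For the measured compounds named here, this is the lowest of the three numbers measured so far. Compound 2 `CCc1ccc(C2=NN(c3ccc(S(C)(=O)=O)cc3)C(=O)CC2)cc1` reaches 46.7%, and compound 3 `COc1ccc(C2=NN(c3ccc(S(C)(=O)=O)cc3)C(=O)CC2)cc1OC` reaches 66.6%; both of these stand above compound 1 by more than the usual scatter of this kind of measurement.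

The unmeasured compound 4 `CS(=O)(=O)c1ccc(N2N=C(c3ccc(Cl)cc3)CCC2=O)cc1` shares the core of compound 1 and differs from it in one place: 4-chlorophenyl in place of 4-hydroxy-2-methylphenyl on a carbon with a double bond to nitrogen. Going by the values given here, one measured step bears directly on this change: a number 13.4 percentage points higher from compound 1 to compound 2 (beyond the scatter), where the same 4-hydroxy-2-methylphenyl group left and another single-ring group entered on a carbon with a double bond to nitrogen. Among the compounds with values here, compound 3, which also carries a different group in place of 4-hydroxy-2-methylphenyl, stands above compound 1 as well, although no single step from compound 1 to compound 3 is counted here. Both replacements of this group moved the read-out upward, so a rise beyond the scatter is expected for compound 4 too, of a size close to the step seen with compound 2.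

Compound 4 is therefore estimated to give 50%, within a range of 35% to 65%. That estimate means an expected step of a number 16.7 percentage points higher from compound 1 to compound 4 (beyond the scatter).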

Compound 4, a percentage reported as inhibition, in the whole organism at one dose (the size of the read-out at that dose, not a potency): 26.6%
The estimate for compound 4 lay 23.4 percentage points above the measured number; the whole stated range lies above it.
By their numbers in this assay, from the lowest: compounds 4 and 1 (each within the scatter of the next); then compound 2; then compound 3.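

In this assay the step from the 4-hydroxy-2-methylphenyl group to 4-chlorophenyl gives a number 6.7 percentage points lower from compound 1 to compound 4 (within the scatter) and so shows no real change, which means that replacing this group does not by itself lift the read-out, as the step to compound 2 alone might have suggested. The comparison of the two single-substituent rings is more telling: chloro in place of ethyl gives a number 20.1 percentage points lower from compound 2 to compound 4 (beyond the scatter) and shows that, with the rest of the molecule held the same, the group carried on the aromatic ring can shift the inhibition of paw edema at this one dose. No measurement is available here to explain why ethyl and chloro differ in this way.

The compounds shown leave open whether a longer chain such as propyl, a fluoro group or an amine on that aromatic carbon would give a number closer to that of ethyl or of chloro. They also leave open what a hydroxy group without the methyl, or a methyl without the hydroxy, would give, so the two parts of the 4-hydroxy-2-methylphenyl group cannot yet be judged separately.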